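From sulfanyl to sulfonyl on a benzyl group

The source may hold more compounds than are shown below. What is called first, only, known or untested is meant among the compounds shown, and "the series" means these compounds.

In a functional assay on DU-145 cells (Homo sapiens) for inhibition, read by trypan blue exclusion, with a stated time of 96 h (on this read-out higher numbers stand for weaker inhibition of growth and lower numbers for stronger inhibition of growth), compound 3 (`COc1cc(OC)c(/C=C(/SCc2ccc(Cl)cc2Cl)C(=O)c2ccc(Cl)cc2)c(OC)c1`) gives 1000 nM as the only number shown. Compound 1 (`COc1cc(OC)c(/C=C(/Sc2ccc(C)cc2)C(=O)c2ccc(Cl)cc2)c(OC)c1`) stands at > 100000 nM which is a limit of the assay. Compound 2 (`COc1cc(OC)c(/C=C(\C(=O)c2ccc(Cl)cc2)S(=O)(=O)c2ccc(Br)cc2)c(OC)c1`) stands at > 100000 nM which is likewise a limit. Compound 4 (`COc1cc(OC)c(/C=C(\C(=O)c2ccc(Cl)cc2)S(=O)(=O)Cc2ccc(F)cc2)c(OC)c1`) has (4-fluorobenzyl)sulfonyl in place of (2,4-dichlorobenzyl)sulfanyl on a double-bonded chain carbon bound to a carbonyl carbon and a double-bonded chain carbon. Compound 2 also bears a sulfonyl, and an at least 100-fold lower number from compound 2 to compound 3 (2.00 log units; beyond the scatter) is a large step, as is an at least 100-fold lower number from compound 1 to compound 3 (2.00 log units; beyond the scatter) while a step that the two limits leave unreadable from compound 1 to compound 2 gives no size. With a benzyl group kept, a moderate move toward weaker inhibition is expected, namely a 5.0-fold higher number from compound 3 to compound 4 (0.70 log units; beyond the scatter) as the estimated step. In this assay compound 4 is estimated at 5000 nM with 700 nM to 60000 nM as the expected range.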

Compound 4, concentration for 50% growth inhibition: 25000 nM
The estimate for compound 4 lay 5.0-fold (0.70 log units) below the measured number, and the stated range covers the measured number.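

In this assay, a sulfonyl on this chain carbon can carry a readable number, though the change brings a 25-fold higher number from compound 3 to compound 4 (1.40 log units; beyond the scatter). A benzyl group on the sulfonyl also stands apart from the aryl groups on sulfur, with an at least 4.0-fold lower number from compound 2 to compound 4 (0.60 log units; beyond the scatter) and an at least 4.0-fold lower number from compound 1 to compound 4 (0.60 log units; beyond the scatter). Those two steps start from a limit: the limit of > 100000 nM in this assay, at which 2 of the 4 values shown sit.

The oxidation state of the sulfur and the ring halogens change together between the two benzyl compounds, so neither change can be credited alone. As far as these compounds go, how an amine or a carboxylic acid on the benzyl ring would read also stays open.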